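Adding an ethoxy group to compound 1

The source may report more compounds than this note shows. Statements on the series, on what has been measured and on what is new or still open speak of the compounds shown alone.

Measured in a functional assay on MDA-MB-468 cells (Homo sapiens) for antiproliferative activity (a higher number here means a weaker inhibitor of growth, a lower number a stronger inhibitor of growth), so far:
compound 1 `COc1ccc(-c2nc3cc(F)ccc3s2)cc1` gives 330 nM of growth inhibition
compound 2 `COc1cc(OC)cc(-c2nc3cc(F)ccc3s2)c1` gives 310 nM of growth inhibition

Compound 1 stands within the scatter of compound 2, so these two numbers set no order. Compound 3 `CCOc1cc(-c2nc3cc(F)ccc3s2)ccc1OC` has not yet been measured. It carries ethoxy in place of hydrogen on an aromatic carbon of compound 1, ortho to a methoxy group. For the measured compounds named here, no measured step covers this change, so a move toward a lower number, beyond the scatter, is expected only tentatively. The expected change is an 11-fold lower number from compound 1 to compound 3 (1.04 log units; beyond the scatter) in this assay for now. For compound 3 the estimated value is 30 nM with an expected range from 1 nM to 350 nM in this measurement.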

Compound 3, concentration for 50% growth inhibition: 92 nM
Estimate against measurement, compound 3: 3.1-fold (0.49 log units) below; measured number inside the range.
By their numbers in this assay, from the lowest: compound 3; then compounds 2 and 1 (each within the scatter of the next).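

In this assay ethoxy in place of hydrogen on an aromatic carbon, ortho to a methoxy group, gives a 3.6-fold lower number from compound 1 to compound 3 (0.55 log units; beyond the scatter) and so provides the only change shown that lies beyond the scatter. This position on the core of compound 1 therefore accepts an ethoxy group, with a modest gain in growth inhibition. Nothing measured here accounts for that gain.

Going by these compounds, whether a longer chain such as propoxy, or an amine, would do the same at this position stays open. Also open, on these data alone, is whether the gain requires the methoxy group.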